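The source may hold more compounds than are shown below. What is called first, only, known or untested is meant among the compounds shown, and "the series" means these compounds.

Measured compounds:
compound 1 `O=C(Nc1ccc(Br)cc1)c1cn(-c2ccccc2)nc1-c1ccccc1`, in a functional assay on HCT-116 cells (Homo sapiens) for cytotoxicity, read by MTT assay, with a stated time of 48 h (on this read-out lower numbers stand for stronger inhibition and higher numbers for weaker inhibition), compound 1 gives 4470 nM
compound 2 `CCOc1ccc(NC(=O)c2cn(-c3ccccc3)nc2-c2ccccc2)cc1`, in this assay compound 2 gives 620 nM

Compound 1 has the highest number of the two; its nearest neighbour is compound 2, with a 7.2-fold lower number from compound 1 to compound 2 (0.86 log units; beyond the scatter). Compound 3 `O=C(Nc1ccc(Br)cc1)c1cn(-c2ccccc2)nc1-c1ccc([N+](=O)[O-])cc1` differs from compound 1 by nitro in place of hydrogen on an aromatic carbon, on the ring that carries no bromo. Within the data shown here, the only measured step, a 7.2-fold lower number from compound 1 to compound 2 (0.86 log units; beyond the scatter), changes the other ring, so it gives no direct guidance for this change. With nothing measured at this position, compound 3 is expected to land close to compound 1, a step of a 1.3-fold lower number from compound 1 to compound 3 (0.11 log units; within the scatter), estimated at 3500 nM within 800 nM to 15000 nM.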

Compound 3, half-maximal inhibitory concentration: 4080 nM
Estimate against measurement, compound 3: 1.2-fold (0.07 log units) below, and the stated range covers the measured number.
By their numbers in this assay, from the lowest: compound 2; then compounds 3 and 1 (each within the scatter of the next).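

With a 1.1-fold lower number from compound 1 to compound 3 (0.04 log units; within the scatter) in this assay, going from phenyl to 4-nitrophenyl leaves the reading unchanged as far as this assay can tell. Among these compounds, this position, on the ring that carries no bromo, therefore tolerates nitro when the bromo is kept, whereas the earlier step showed only that the other ring matters. No measurement at hand offers an explanation for this flat result.

As far as these compounds go, whether an amine or a carboxylic acid at this place would behave the same stays open. So does whether nitro would also leave the number unchanged alongside ethoxy, as in compound 2.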